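Removing the Ring-Nitrogen Cyclopropyl From Compound 3

The source may hold more compounds than are shown below. What is called first, only, known or untested is meant among the compounds shown, and "the series" means these compounds.

Compound 1, `Fc1cc2nc(-c3cccnc3)n(C3CC3)c2cc1F`, gives 370 nM in an assay on V79 cells for inhibition of cytochrome P450 11B1, mitochondrial (Homo sapiens), read by HTRF, with a stated time of 1 h; a lower number here means a stronger inhibitor, a higher number a weaker inhibitor.
Compound 2, `c1cncc(-c2nc3ccccc3n2C2CC2)c1`, reaches only an assay limit of > 8330 nM in this assay.
Compound 3, `Fc1ccc2nc(-c3cccnc3)n(C3CC3)c2c1`, gives 401 nM in this assay.

Compound 3 and compound 1 sit close together: a 1.1-fold higher number from compound 1 to compound 3 (0.03 log units; within the scatter). For the measured compounds named here, the only other value, that of compound 2, is a limit rather than a number (the limit of > 8330 nM in this assay, at which 1 of the 3 values shown sits). Going the other way, an at least 20-fold lower number from compound 2 to compound 3 (1.31 log units; beyond the scatter), so compound 3 is clearly apart from compound 2, though how far cannot be said.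

Compound 4, `Fc1ccc2nc(-c3cccnc3)[nH]c2c1`, differs from compound 3 in one place: hydrogen in place of cyclopropyl on an aromatic nitrogen. Neither measured step touches this position; both concern fluoro against hydrogen on an aromatic carbon, one of them within the scatter and the other large. The change to compound 4 therefore has no direct precedent among these compounds, and an expectation rests only on the fact that a three-carbon group disappears from the shared core.

Compound 4 is estimated to give 1200 nM in this assay, with a range of 300 nM to 5000 nM. This expectation amounts to a 3.0-fold higher number from compound 3 to compound 4 (0.48 log units; beyond the scatter), and is held with little confidence.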

Compound 4, half-maximal inhibitory concentration: 1990 nM
Beside the measured number, compound 4's estimate is 1.7-fold (0.22 log units) below it, and the stated range covers the measured number.
By their numbers in this assay, from the lowest: compounds 1 and 3 (each within the scatter of the next); then compound 4. At a limit, above all of these: compound 2.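

For the compounds shown here, the earlier steps all concerned fluoro against hydrogen on an aromatic carbon, so this is the first look at the aromatic nitrogen of the five-membered ring. In this assay, replacing cyclopropyl with hydrogen there gives a 5.0-fold higher number from compound 3 to compound 4 (0.70 log units; beyond the scatter), a modest loss that lies beyond the scatter, so the group on this nitrogen does affect inhibition, though compound 4 still gives a real number and not an assay limit, and the cyclopropyl is therefore helpful but not essential. Nothing among the data shown explains why removing this group weakens inhibition.

Going by these compounds, it remains open whether the gain comes from the three-membered ring itself or from any carbon group on this nitrogen, a question that a methyl, an ethyl or a longer chain such as butyl in the same place would address. On these data alone, it is also open whether the step would keep its size on the core of compound 1, which carries a second fluoro, or on the core of compound 2, which carries none.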